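Replacing the aromatic group: from compound 1 to compound 4

The source may hold more compounds than are shown below. What is called first, only, known or untested is meant among the compounds shown, and "the series" means these compounds.

Compound 1 `COC1=C(C)C(=O)/C(=C(O)/C=C/c2ccc(Br)cc2)C(=O)C1(C)C` gives 9 ug/mL in a functional assay on A-431 cells (Homo sapiens) for cytotoxicity; on this read-out lower numbers stand for an effect already at smaller amounts and higher numbers for an effect only at larger amounts of compound.
Compound 2 `COC1=C(C)C(=O)/C(=C(O)/C=C/c2ccc(O)cc2)C(=O)C1(C)C` gives 14.9 ug/mL in this assay.
Compound 3 `CCc1ccc(/C=C/C(O)=C2/C(=O)C(C)=C(OC)C(C)(C)C2=O)cc1` gives 12 ug/mL in this assay.

Among these three numbers, compound 1 has the lowest, yet its two steps to the other compounds, a 1.3-fold higher number from compound 1 to compound 3 (0.12 log units; within the scatter) and a 1.7-fold higher number from compound 1 to compound 2 (0.22 log units; within the scatter), both fall within the scatter, as does the remaining step of a 1.2-fold lower number from compound 2 to compound 3 (0.09 log units; within the scatter). The three measured compounds therefore cannot be told apart in this assay.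

Compound 4 `C=Cc1ccccc1/C=C/C(O)=C1/C(=O)C(C)=C(OC)C(C)(C)C1=O` has not been measured. It differs from compound 1 as follows: 2-vinylphenyl in place of 4-bromophenyl on a double-bonded chain carbon bound to a double-bonded chain carbon. The measured steps bear on this only loosely: each of them exchanges one substituent on the aromatic ring for another, whereas compound 4 exchanges the whole aromatic group, and none of them puts a substituent where the vinyl of compound 4 sits. Since every measured exchange on the aromatic ring stayed within the scatter, no step beyond the scatter is expected in this assay here either, in no particular direction, but with wider uncertainty.

Compound 4 is therefore estimated at 11 ug/mL, with a range of 4 ug/mL to 30 ug/mL. This estimate means an expected step of a 1.2-fold higher number from compound 1 to compound 4 (0.09 log units; within the scatter).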

Compound 4, concentration for half-maximal effect: 2.6 ug/mL
Estimate against measurement, compound 4: 4.2-fold (0.63 log units) above; measured number outside the range, below it.
By their numbers in this assay, from the lowest: compound 4; then compounds 1, 3 and 2 (each within the scatter of the next).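

Exchanging the whole aromatic group on a double-bonded chain carbon bound to a double-bonded chain carbon moved the number in this assay beyond the scatter, which no exchange among compound 1, compound 2 and compound 3 had done: the steps are (a 3.5-fold lower number from compound 1 to compound 4 (0.54 log units; beyond the scatter)), (a 4.6-fold lower number from compound 3 to compound 4 (0.66 log units; beyond the scatter)) and (a 5.7-fold lower number from compound 2 to compound 4 (0.76 log units; beyond the scatter)). Compound 4, with its 2-vinylphenyl, is thus the only one of the four set apart from all the others, and so the lowest number goes with this group rather than with any of the three groups compared before. Nothing shown gives a reason for this result.

Whether the vinyl itself or its place on the aromatic ring accounts for the step stays open, since compound 4 differs from the others in both at once. Also open, as far as these compounds go, is how an amine, a carboxylic acid or a longer chain in place of the vinyl would read in this assay on this aromatic ring.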